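The source may hold more compounds than are shown below. What is called first, only, known or untested is meant among the compounds shown, and "the series" means these compounds.

Three compounds have been measured in a functional assay on U-87MG ATCC cells for antiproliferative activity against U-87 MG (Homo sapiens), read by MTT assay, with a stated time of 48 h, tested at 10 uM; on this read-out lower numbers stand for a stronger effect and higher numbers for a weaker effect at the one concentration tested:

Compound 1, `COc1cccc(-c2nc(SCC(=O)c3sc(-c4ccccc4)nc3C)[nH]c(=O)c2C#N)c1`, gives 90.2%.
Compound 2, `Cc1nc(-c2ccc(Cl)cc2)sc1C(=O)CSc1nc(-c2cccc(Cl)c2)c(C#N)c(=O)[nH]1`, gives 95.2%.
Compound 3, `Cc1nc(-c2ccccc2)sc1C(=O)CSc1nc(-c2ccc(Cl)c(Cl)c2)c(C#N)c(=O)[nH]1`, gives 92.5%.

Compound 3 stands second among these three numbers, with compound 1 nearest and compound 2 furthest, and both gaps lie within the usual scatter of this assay, so the three compounds cannot be told apart on these readings. The next compound, compound 4, `Cc1nc(-c2ccccc2)sc1C(=O)CSc1nc(-c2cccc(Cl)c2)c(C#N)c(=O)[nH]1`, differs from compound 3 in one place: hydrogen in place of chloro on an aromatic carbon.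

Going by the values given here, only one measured step bears on this change, the exchange of the same aromatic group between compound 1 and compound 3, which gave a number 2.3 percentage points higher from compound 1 to compound 3 (within the scatter). Compound 2 carries the same 3-chlorophenyl group as compound 4 but differs from it in another place, and its value sits within the scatter of compound 3 as well. Every reading so far is high, meaning weak effect at the concentration tested, and nothing in these numbers suggests that removing one chloro group should move the reading beyond the scatter. The step is expected to be a number 0.5 percentage points higher from compound 3 to compound 4 (within the scatter), no real change. Compound 4 is therefore estimated to give 93%, expected to fall between 84% and 101%.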

Compound 4, a percentage reported as activity, at one concentration (the size of the read-out at that concentration, not a potency): 83.7%
Beside the measured number, compound 4's estimate is 9.3 percentage points above it; the whole stated range lies above it.
By their numbers in this assay, from the lowest: compounds 4, 1, 3 and 2 (each within the scatter of the next, the first and the last beyond it).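

In this assay, taking one chloro away from the 3,4-dichlorophenyl group gives a number 8.8 percentage points lower from compound 3 to compound 4 (within the scatter), so this position shows no clear effect of the change. Chloro in place of methoxy at the same kind of aromatic carbon gives a number 6.5 percentage points lower from compound 1 to compound 4 (within the scatter), which is equally unresolved. Going by these compounds alone, the same loss of a chloro on the other aromatic ring gives a number 11.5 percentage points lower from compound 2 to compound 4 (beyond the scatter), the first step in this set to pass the scatter, though it is only modest.

Nothing measured here explains these shifts. Going by these compounds, it remains open whether a larger change at this position, such as an amine or a carboxylic acid on the ring, would lower the reading in this assay well beyond the scatter.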